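Same Atoms, Joined Differently: From Compound 2 to Compound 3

The source may report more compounds than this note shows. Statements on the series, on what has been measured and on what is new or still open speak of the compounds shown alone.

Among the measured compounds shown here, only one firm number is available here. In an ADME assay on CHO cells (Cricetulus griseus) for cytotoxicity, read by MTT assay (on this read-out higher numbers stand for weaker inhibition and lower numbers for stronger inhibition), compound 1 (`C[S+]([O-])c1ccc(-c2cnc3ccc(Nc4cccc(S(C)(=O)=O)c4)nn23)cc1`) gives 123000 nM. As far as these compounds go, compound 2 (`C[S+]([O-])c1ccc(-c2cnc3ccc(Nc4cccc([S+](C)[O-])c4)nn23)cc1`) has no single number, since its entry reads "not determined" (no result reported), so its place on this scale is unknown. Compound 3 (`C[S+]([O-])c1ccc(Nc2ccc3ncc(-c4ccc([S+](C)[O-])cc4)n3n2)cc1`) has not yet been tested. The structural change is a group of 9 heavy atoms (7 carbon, 1 oxygen, 1 sulfur; one six-membered aromatic ring of carbon only) in place of a group of 9 heavy atoms (7 carbon, 1 oxygen, 1 sulfur; one six-membered aromatic ring of carbon only), on a nitrogen on an aromatic ring. The group that leaves and the group that enters hold the same atoms, joined differently, and the rest of the molecule stays the same. For the measured compounds named here, no measured step shows what such a change does. Going by the values given here, the only guide is compound 1 at 123000 nM, and no shift beyond the usual scatter from that level is expected in this assay. For compound 3 the estimated value is 100000 nM, with an expected range from 40000 nM to 250000 nM.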

Compound 3, half-maximal inhibitory concentration: > 244000 nM
Compound 3 was reported as a limit (the forecaster's own chance of this, stated with the estimate: 30%); middle value at least 2.4-fold (0.38 log units) away from the limit.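

Among the compounds shown here, compound 2 has no single number in this assay, so no step to compound 3 can be read. Compound 3 gives > 244000 nM, which is a limit and not a number. As far as these compounds go, what joining the same atoms differently does to this read-out stays open.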